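The source may report more compounds than this note shows. Statements on the series, on what has been measured and on what is new or still open speak of the compounds shown alone.

Measured in a functional assay on PC-3 cells (Homo sapiens) for antiproliferative activity, read by MTT assay, with a stated time of 48 h; on this read-out lower numbers stand for stronger inhibition and higher numbers for weaker inhibition:
- compound 1 `c1ccc(-c2nnc(-c3cn4ccccc4n3)o2)cc1`: 22200 nM
- compound 2 `Clc1ccc(-c2nnc(-c3cn4ccccc4n3)o2)cc1`: 33700 nM
- compound 3 `Cc1cc(Br)c2nc(-c3nnc(-c4ccccc4)o3)cn2c1`: 17800 nM

Compound 3 lies within the usual scatter of both compound 1 and compound 2, so the three values cannot be ranked. Compound 4 `Cc1cc(Br)c2nc(-c3nnc(-c4ccc(Cl)cc4)o3)cn2c1` carries chloro in place of hydrogen on an aromatic carbon, para to a large group, taking phenyl to 4-chlorophenyl: chloro in place of hydrogen on an aromatic carbon. Going by the values given here, the only measured step of this kind is a 1.5-fold higher number from compound 1 to compound 2 (0.18 log units; within the scatter), and it was made on a different core, so it serves only as a guide. No step beyond the scatter is therefore expected in this assay. The expected step is a 1.4-fold higher number from compound 3 to compound 4 (0.15 log units; within the scatter). For compound 4 the estimated value is 25000 nM, with an expected range of 12000 nM to 50000 nM.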

Compound 4, half-maximal inhibitory concentration: 42000 nM
For compound 4 the middle estimate is 1.7-fold (0.23 log units) below the measured one; the measured number falls inside the stated range.
By their numbers in this assay, from the lowest: compounds 3, 1, 2 and 4 (each within the scatter of the next, the first and the last beyond it).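

In this assay, going by these compounds alone, chloro in place of hydrogen on an aromatic carbon, para to a large group, gives a 2.4-fold higher number from compound 3 to compound 4 (0.37 log units; beyond the scatter) as the first step of this change beyond the scatter, towards weaker inhibition. The direction is the same on both cores, and the size does not separate them: the same change on two cores in this assay, a 1.5-fold higher number (0.18 log units; within the scatter) from compound 1 to compound 2 and a 2.4-fold higher number (0.37 log units; beyond the scatter) from compound 3 to compound 4, 1.6-fold (0.19 log units) apart, within the scatter of two such steps

Still open, as far as these compounds go, is whether the loss belongs to chloro alone or extends to other groups at this position, such as methoxy, an amine or a carboxylic acid. From the compounds shown here alone, whether any group here gives stronger inhibition than hydrogen also remains open.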